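Ethyl to sec-butyl on an aromatic nitrogen

The source may report more compounds than this note shows. Statements on the series, on what has been measured and on what is new or still open speak of the compounds shown alone.

Of the compounds shown here, three sharing one core have been tested in a functional assay on DU-145 cells (Homo sapiens) for inhibition, read by WST assay, with a stated time of 3 days; on this read-out lower numbers stand for stronger inhibition and higher numbers for weaker inhibition. Compound 1 (`Cn1ccnc1/C=C/C(=O)/C=C/c1coc2ccccc2c1=O`), with methyl on an aromatic nitrogen, gives 4500 nM. Compound 2 (`CCn1ccnc1/C=C/C(=O)/C=C/c1coc2ccccc2c1=O`), with ethyl there, gives 3000 nM. Compound 3 (`CC(C)n1ccnc1/C=C/C(=O)/C=C/c1coc2ccccc2c1=O`), with isopropyl there, gives 3300 nM. Compound 2 therefore lies within the usual scatter of both others, so these numbers do not separate the three.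

On these data alone, compound 4 (`CCC(C)n1ccnc1/C=C/C(=O)/C=C/c1coc2ccccc2c1=O`) is still untested. It is made from compound 2 by one change, ethyl in place of hydrogen on a saturated chain carbon bound to an aromatic nitrogen and a saturated chain carbon, which turns ethyl into sec-butyl. Among the measured compounds shown here, the closest precedent puts methyl on that same carbon, a 1.1-fold higher number from compound 2 to compound 3 (0.04 log units; within the scatter). The other two steps, a 1.5-fold lower number from compound 1 to compound 2 (0.18 log units; within the scatter) and a 1.4-fold lower number from compound 1 to compound 3 (0.13 log units; within the scatter), are just as small. None of the tested compounds carries ethyl on that carbon, so the range must stay wide. In this assay the expected step is a 1.1-fold higher number from compound 2 to compound 4 (0.03 log units; within the scatter), which would be no change beyond the scatter. For compound 4 the estimated value is 3200 nM, with an expected range from 1600 nM to 6400 nM.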

Compound 4, half-maximal inhibitory concentration: 3300 nM
Compound 4: middle estimate off by 1.0-fold (0.01 log units), on the low side; the measured number falls inside the stated range.
By their numbers in this assay, from the lowest: compounds 2, 3, 4 and 1 (each within the scatter of the next).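

In this assay sec-butyl on the aromatic nitrogen reads as a 1.1-fold higher number from compound 2 to compound 4 (0.04 log units; within the scatter) and as no change at the digits printed from compound 3 to compound 4 (within the scatter) and as a 1.4-fold lower number from compound 1 to compound 4 (0.13 log units; within the scatter) so the series now reaches a group larger than isopropyl with no step beyond the scatter. Among the compounds shown here, this position therefore carries ethyl on the saturated chain carbon bound to the aromatic nitrogen without any measurable shift in this read-out, something the earlier compounds could not show. Adding one methyl also gives steps that agree on two different starting compounds: the same change on two cores in this assay, a 1.5-fold lower number (0.18 log units; within the scatter) from compound 1 to compound 2 and no change at the digits printed (within the scatter) from compound 3 to compound 4, 1.5-fold (0.18 log units) apart, within the scatter of two such steps.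

On these data alone, all four compounds carry only plain carbon chains on this nitrogen, so an amine or a carboxylic acid at the end of a longer chain remains open. Also open, as far as these compounds go, is whether a phenyl ring or a much longer chain there would move the number beyond the scatter.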